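The source may hold more compounds than are shown below. What is called first, only, known or untested is meant among the compounds shown, and "the series" means these compounds.

For the measured compounds named here, in an ADME assay on Vero cells (Chlorocebus sabaeus) for cytotoxicity, with a stated time of 72 h (a lower number here means a stronger inhibitor, a higher number a weaker inhibitor), compound 2 (`O=C(CCN1CCN(c2ccc([N+](=O)[O-])cc2)CC1)c1ccc2ccccc2c1`) gives 74300 nM, the higher of the two numbers so far, while compound 1 (`O=C(CCN1CCN(c2ccc(C(F)(F)F)cc2)CC1)c1ccc2ccccc2c1`) gives 30100 nM. Compound 3 (`O=C(CCN1CCN(c2ccc(F)cc2)CC1)c1ccc2ccccc2c1`) carries fluoro in place of nitro on an aromatic carbon, para to a large group: fluoro in place of nitro on an aromatic carbon. Going by the values given here, only one measured step touches this place, and it is modest: a 2.5-fold higher number from compound 1 to compound 2 (0.39 log units; beyond the scatter), with nitro replacing trifluoromethyl. A step of similar modest size is therefore expected in this assay, toward a lower number, and the expected change is a 1.9-fold lower number from compound 2 to compound 3 (0.27 log units; within the scatter). For compound 3 the estimated value is 40000 nM, with an expected range of 18000 nM to 85000 nM.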

Compound 3, half-maximal inhibitory concentration: 103000 nM
Compound 3: the middle estimate sits 2.6-fold (0.41 log units) below what was measured; measured number above the stated range.
By their numbers in this assay, from the lowest: compound 1; then compounds 2 and 3 (each within the scatter of the next).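

In this assay the exchange of nitro for fluoro at this position does not separate the two groups (a 1.4-fold higher number from compound 2 to compound 3 (0.14 log units; within the scatter)), although the earlier step from trifluoromethyl to nitro lay beyond the scatter. Trifluoromethyl stands apart from fluoro as well (a 3.4-fold higher number from compound 1 to compound 3 (0.53 log units; beyond the scatter)), so compound 1 has the lowest number of the three. Nothing measured here gives a reason for this. Open, going by these compounds, is how an amine or a methoxy group would read at this position, and whether chloro would fall with trifluoromethyl or with fluoro.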